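This account rests on a few compounds, and the source may have more. Where it says the series, first, only, none or still open, it means among the compounds named here.

Measured so far in a functional assay on ZR-75-1 cells (Homo sapiens) for cytotoxicity, read by sulforhodamine B assay, with a stated time of 3 days; on this read-out lower numbers stand for an effect already at smaller amounts and higher numbers for an effect only at larger amounts of compound:

compound 1, `COCc1c(C)coc1-c1ccc2c(c1OC)CCCC2(C)C`, gives 14.3 uM
compound 2, `CCOCc1c(C)coc1-c1ccc2c(c1OC)CCCC2(C)C`, gives 19.8 uM
compound 3, `COc1c(-c2occ(C)c2C(=O)O)ccc2c1CCCC2(C)C`, gives 41.4 uM

Compound 3 stands at the highest number of the three in this assay; the nearest is compound 2, with a 2.1-fold higher number from compound 2 to compound 3 (0.32 log units; beyond the scatter), and the furthest is compound 1, with a 2.9-fold higher number from compound 1 to compound 3 (0.46 log units; beyond the scatter). Between compound 1 and compound 2 the step is a 1.4-fold higher number from compound 1 to compound 2 (0.14 log units; within the scatter), so the two ether-bearing compounds are not separated.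

Compound 4, `COc1c(-c2occ(C)c2CO)ccc2c1CCCC2(C)C`, has not yet been measured. It differs from compound 3 as follows:
hydroxymethyl in place of carboxy on an aromatic carbon

Among the compounds with values here, the steps that bear on this change are those from compound 1 and from compound 2 to compound 3, where the carboxy group stood against methoxymethyl or ethoxymethyl and gave modest rises in number. Hydroxymethyl keeps one hydrogen-bond donor and one hydrogen-bond acceptor, as carboxy did, but loses the double bond outside aromatic rings and one oxygen; it is nearer in size to the methoxymethyl of compound 1. Within the data shown here, the step from compound 3 to compound 4 in this assay is therefore expected to run toward lower numbers, modest in size, near the reverse of a 2.9-fold higher number from compound 1 to compound 3 (0.46 log units; beyond the scatter) or a 2.1-fold higher number from compound 2 to compound 3 (0.32 log units; beyond the scatter) but with no direct precedent for a hydroxymethyl.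

Compound 4 is estimated at 22 uM, range 9 uM to 50 uM, which means an expected step of a 1.9-fold lower number from compound 3 to compound 4 (0.27 log units; within the scatter).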

Compound 4, concentration for half-maximal effect: 15 uM
For compound 4 the middle estimate is 1.5-fold (0.17 log units) above the measured one; the measured number falls inside the stated range.
By their numbers in this assay, from the lowest: compounds 1, 4 and 2 (each within the scatter of the next); then compound 3.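

In this assay, hydroxymethyl in place of carboxy on this aromatic carbon gives a 2.8-fold lower number from compound 3 to compound 4 (0.44 log units; beyond the scatter), although both groups count as 1 hydrogen-bond donor, 1 hydrogen-bond acceptor and no net charge, so these counts alone do not track the change in number at this position. With hydrogen in place of methyl on the oxygen the step is a 1.0-fold higher number from compound 1 to compound 4 (0.02 log units; within the scatter), and with hydrogen in place of ethyl on that oxygen it is a 1.3-fold lower number from compound 2 to compound 4 (0.12 log units; within the scatter), so hydroxymethyl, methoxymethyl and ethoxymethyl are not separated here, and among the four groups at this position only carboxy stands apart from the others beyond the scatter. Nothing available accounts for the step from carboxy to hydroxymethyl or for the absence of a separation among the three oxygen-bearing chains.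

Still open, from the compounds shown here alone, is what an aminomethyl group or a primary amide would give on this aromatic carbon, and whether a longer chain such as butyl on the oxygen would stay level with the methyl and ethyl ethers. Going by these compounds, the methyl ester of the carboxylic acid is also open, and it would show whether the higher number of compound 3 persists once the acid hydrogen is replaced.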